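This account rests on a few compounds, and the source may have more. Where it says the series, first, only, none or still open, it means among the compounds named here.

Measured compounds:

Compound 1, `O=C(COc1c(-c2ccccc2)oc2ccccc2c1=O)Nc1ccc(F)cc1`. In a functional assay on NCI-H661 cells (Homo sapiens) for antiproliferative activity, read by MTT assay, with a stated time of 72 h (a lower number here means a stronger inhibitor of growth, a higher number a weaker inhibitor of growth), compound 1 gives only a limit, > 10000 nM.

Compound 2, `COc1ccc(NC(=O)COc2c(-c3ccccc3)oc3ccccc3c2=O)cc1`. In this assay compound 2 gives 6740 nM.

Compound 3, `O=C(COc1ccc2c(=O)c(-c3ccccc3)coc2c1)Nc1ccc(F)cc1`. In this assay compound 3 gives only a limit, > 10000 nM.

Compounds 1 and 2 share one core and differ in a single place: methoxy in place of fluoro on an aromatic carbon. That change gave an at least 1.4-fold lower number from compound 1 to compound 2 (0.17 log units; that floor lies within the scatter). The step has a floor rather than a full size because the limit of > 10000 nM in this assay, at which 2 of the 3 values shown sit, is where compound 1 sits, so only the value of compound 2 is a number.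

Compound 3 is built from the same atoms as compound 1, joined differently; the difference between the two cores is not broken down here. Compound 4, `COc1ccc(NC(=O)COc2ccc3c(=O)c(-c4ccccc4)coc3c2)cc1`, stands to compound 3 exactly as compound 2 stands to compound 1: the change is methoxy in place of fluoro on an aromatic carbon, the same change, at the same kind of place in both pairs.

What can be expected for compound 4 therefore rests on one measured step, whose lower bound is all that is known, applied to a starting point that is itself a limit. The account expects compound 4 to show 8000 nM in this assay, with a likely range from 3000 nM to 20000 nM. This expectation for compound 4 corresponds to an estimated step of an at least 1.2-fold lower number from compound 3 to compound 4 (0.09 log units; that floor lies within the scatter), and it carries a real chance that the assay again returns only a limit for compound 4.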

Compound 4, concentration for 50% growth inhibition: 9530 nM
Estimate against measurement, compound 4: 1.2-fold (0.08 log units) below; the measured number falls inside the stated range.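

On the second core, putting 4-methoxyphenyl in place of 4-fluorophenyl gives an at least 1.0-fold lower number from compound 3 to compound 4 (0.02 log units; that floor lies within the scatter) in this assay. In each pair the fluoro compound gives only a limit, so each step is a floor rather than a full size, and the two can be set side by side only as floors: the same change on two cores in this assay, an at least 1.4-fold lower number (0.17 log units; that floor lies within the scatter) from compound 1 to compound 2 and an at least 1.0-fold lower number (0.02 log units; that floor lies within the scatter) from compound 3 to compound 4; the limit leaves it open whether they differ. The pairs show that on both cores the methoxy compound gives a number where the fluoro compound gives only a limit, but they do not show that either step exceeds the usual scatter, or that the change carries over from one core to the other with the same size, as both fluoro compounds sit at one shared limit: the limit of > 10000 nM in this assay, at which 2 of the 4 values shown sit.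

The compounds shown leave open how this series would read in this assay with an amine or a carboxylic acid in place of the fluoro or methoxy group, or with a longer chain in place of the one that carries the amide. They also leave open the true size of the step on either core, which only a fluoro partner with a number rather than a limit could give.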